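The compounds below may be only part of what the source reports. "The series", "measured", "known", "first", "only" and "open" are said of these compounds alone.

Measured in a functional assay (Nicotiana tabacum); a higher number here means a weaker inhibitor, a lower number a stronger inhibitor:
- Compound 1 `CSc1nc(NC2CCC2)c2cccnc2n1`: 720 nM
- Compound 2 `CSc1nc(NCc2ccccc2)c2cccnc2n1`: 25200 nM
- Compound 3 `CSc1nc(Nc2ccc(F)cc2)c2cccnc2n1`: 2620 nM

The three compounds share a core and differ in the group on the amine nitrogen. Compound 3, at 2620 nM, holds the middle place of the three numbers. Compound 1 lies lower and compound 2 lies higher, and both gaps are beyond the scatter.

The next compound is compound 4 `CCc1ccc(Nc2nc(SC)nc3ncccc23)cc1`. It carries ethyl in place of fluoro on an aromatic carbon, para to a large group: ethyl in place of fluoro on an aromatic carbon. Going by the values given here, no two measured compounds differ in one place only, so the data give no direct guide to this exchange. The wide spread among the three measured compounds does, however, argue for a generous range. In this assay, no step beyond the scatter is expected, with any drift toward a slightly higher number. The estimated change is a 1.1-fold higher number from compound 3 to compound 4 (0.06 log units; within the scatter). For compound 4 the estimated value is 3000 nM, with an expected range from 1000 nM to 9000 nM.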

Compound 4, half-maximal inhibitory concentration: 7150 nM
The estimate for compound 4 lay 2.4-fold (0.38 log units) below the measured number, within the range that was stated.
By their numbers in this assay, from the lowest: compound 1; then compound 3; then compound 4; then compound 2.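

In this assay, going by these compounds alone, putting ethyl in place of fluoro on the aromatic carbon para to a large group gives a 2.7-fold higher number from compound 3 to compound 4 (0.44 log units; beyond the scatter) and is the first comparison here in which the compounds differ in one place only. This position therefore responds to the group it carries: of the two groups seen there, fluoro goes with the lower number and ethyl with the higher, and the step lies beyond the scatter. Nothing shown here explains why the number rises with this exchange.

A single step cannot tell whether the rise follows the arrival of ethyl or the departure of fluoro. Methyl, chloro or an amine at this place could separate those two readings, and propyl would show whether a longer chain moves the number further in the same direction.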